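The source may hold more compounds than are shown below. What is called first, only, known or untested is meant among the compounds shown, and "the series" means these compounds.

In an ADME assay on Vero 76 cells (Chlorocebus sabaeus) for cytotoxicity, read by MTT assay, with a stated time of 96 h (a higher number here means that more compound is tolerated, a lower number that less compound is tolerated), compound 1 (`NS(=O)(=O)c1ccc(N2N=C(c3ccc(Oc4ccccc4)cc3)CC2c2ccccc2)cc1`) gives 85000 nM, compound 2 (`Cc1cccc(C2CC(c3ccc(Oc4ccccc4)cc3)=NN2c2ccc(S(N)(=O)=O)cc2)c1`) gives 81000 nM and compound 3 (`NS(=O)(=O)c1ccc(N2N=C(c3ccc(Oc4ccccc4)cc3)CC2c2ccccc2Cl)cc1`) gives 29000 nM, the lowest of the three numbers. Compound 4 (`NS(=O)(=O)c1ccc(N2N=C(c3ccc(Oc4ccccc4)cc3)CC2c2cccc(Cl)c2)cc1`) carries 3-chlorophenyl in place of 2-chlorophenyl on a saturated ring carbon. For the measured compounds named here, three measured steps bear on this change. The step to the 3-methylphenyl group was a 1.0-fold lower number from compound 1 to compound 2 (0.02 log units; within the scatter), while the 2-chlorophenyl group went with a 2.9-fold lower number from compound 1 to compound 3 (0.47 log units; beyond the scatter) and with a 2.8-fold lower number from compound 2 to compound 3 (0.45 log units; beyond the scatter). Going by the values given here, no 3-chlorophenyl compound has been measured, so compound 4 is expected to fall between compound 3 and compound 2. The expected step is a 1.9-fold higher number from compound 3 to compound 4 (0.28 log units; within the scatter). For compound 4 the estimated value is 55000 nM, with an expected range from 25000 nM to 100000 nM.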

Compound 4, half-maximal cytotoxic concentration: 88000 nM
For compound 4 the middle estimate is 1.6-fold (0.20 log units) below the measured one; low and high end bracket the measured number.
By their numbers in this assay, from the lowest: compound 3; then compounds 2, 1 and 4 (each within the scatter of the next).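

In this assay the change from 2-chlorophenyl to 3-chlorophenyl gives a 3.0-fold higher number from compound 3 to compound 4 (0.48 log units; beyond the scatter) with the same atoms, so the lower number of compound 3 goes with the 2-chlorophenyl group and not with chloro on this phenyl ring as such. The 3-chlorophenyl group stays within the scatter of the other two groups, with a 1.1-fold higher number from compound 2 to compound 4 (0.04 log units; within the scatter) and a 1.0-fold higher number from compound 1 to compound 4 (0.02 log units; within the scatter) as its steps. No measurement at hand explains the difference between the two chlorophenyl isomers.

On these data alone, whether a methoxy group or an amine in place of the chloro of compound 3 would give the same lower number stays open.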